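Swapping 2,4-dimethoxyphenyl for 4-ethylphenyl in growth inhibition

This account rests on a few compounds, and the source may have more. Where it says the series, first, only, none or still open, it means among the compounds named here.

Compound 1 (`COc1cc(/C=C/C(=O)C(=Cc2ccc(OC)c(OC)c2)C(=O)/C=C/c2ccc(O)c(OC)c2)ccc1O`) gives 430 nM
Compound 2 (`COc1ccc(C=C(C(=O)/C=C/c2ccc(O)c(OC)c2)C(=O)/C=C/c2ccc(O)c(OC)c2)c(OC)c1`) gives 690 nM

Going by the values given here, in a functional assay on A549 cells (Homo sapiens) for inhibition, read by sulforhodamine B assay, with a stated time of 48 h (a higher number here means a weaker inhibitor of growth, a lower number a stronger inhibitor of growth), compound 2 gives 690 nM and lies within the scatter of compound 1, its only comparison, at 430 nM on this scale. Compound 3 (`CCc1ccc(C=C(C(=O)/C=C/c2ccc(O)c(OC)c2)C(=O)/C=C/c2ccc(O)c(OC)c2)cc1`) carries 4-ethylphenyl in place of 2,4-dimethoxyphenyl on a double-bonded chain carbon bound to a double-bonded chain carbon. Among the compounds with values here, the only measured step (a 1.6-fold higher number from compound 1 to compound 2 (0.21 log units; within the scatter)) changed the same place and stayed within the scatter, but it exchanged one dimethoxyphenyl for another, so it offers limited guidance. No step beyond the scatter is therefore expected in this assay in either direction. The estimated step (a 1.2-fold lower number from compound 2 to compound 3 (0.06 log units; within the scatter)) is small. Compound 3 is expected at 600 nM (estimated range 250 nM to 1400 nM).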

Compound 3, concentration for 50% growth inhibition: 550 nM
Compound 3: middle estimate off by 1.1-fold (0.04 log units), on the high side; the measured number falls inside the stated range.
By their numbers in this assay, from the lowest: compounds 1, 3 and 2 (each within the scatter of the next).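

In this assay, placing 4-ethylphenyl on a double-bonded chain carbon bound to a double-bonded chain carbon gives a 1.3-fold lower number from compound 2 to compound 3 (0.10 log units; within the scatter) and a 1.3-fold higher number from compound 1 to compound 3 (0.11 log units; within the scatter). Unlike either dimethoxyphenyl group, 4-ethylphenyl carries no oxygen, so at this position an oxygen-free group stays within the scatter of both. Nothing available accounts for this result. Going by these compounds, it remains open whether a phenyl ring bearing an amine or a carboxylic acid, or a chain longer than ethyl, would also stay within the scatter here.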